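The source may hold more compounds than are shown below. What is called first, only, known or untested is meant among the compounds shown, and "the series" means these compounds.

Compound 1, `CCCNC(=O)Nc1c(OCCCn2cnc(-c3ccccc3)c2)cccc1N(C)C`: 7230 nM
Compound 2, `CCCCCNC(=O)Nc1c(OCCCn2cnc(-c3ccccc3)c2)cccc1N(C)C`: 160 nM

Among the compounds with values here, in an assay on aorta for inhibition of acyl-CoA:cholesterol acyltransferase (Oryctolagus cuniculus) (a lower number here means a stronger inhibitor, a higher number a weaker inhibitor), compound 2 gives 160 nM, the lowest of the two numbers known here, while compound 1 gives 7230 nM. Within the data shown here, the only measured step, a 45-fold lower number from compound 1 to compound 2 (1.66 log units; beyond the scatter), is large and came from ethyl in place of hydrogen on a saturated chain carbon, three bonds along the chain from an amide-type nitrogen. Compound 3, `CCCCCNC(=O)Nc1c(OCCCn2cnc(-c3ccc(CCCC)cc3)c2)cccc1N(C)C`, differs from compound 2 by butyl in place of hydrogen on an aromatic carbon. Among the measured compounds shown here, no measured step touches the phenyl ring, so the step from compound 1 to compound 2 bears on this change only loosely, as a sign that added chain carbon elsewhere in the molecule went with a lower number in this assay. Compound 3 is therefore expected to give a step of about a 2.0-fold lower number from compound 2 to compound 3 (0.30 log units; within the scatter) toward a somewhat lower number, though a change within the scatter is nearly as likely. The estimate for compound 3 is 80 nM, within a range from 15 nM to 500 nM.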

Compound 3, half-maximal inhibitory concentration: 430 nM
Estimate against measurement, compound 3: 5.4-fold (0.73 log units) below; low and high end bracket the measured number.
By their numbers in this assay, from the lowest: compound 2; then compound 3; then compound 1.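

In this assay, the change from phenyl to 4-butylphenyl gives a 2.7-fold higher number from compound 2 to compound 3 (0.43 log units; beyond the scatter) and so runs against the earlier hint from the other end of the molecule, where the longer chain on the amide-type nitrogen gave a 45-fold lower number from compound 1 to compound 2 (1.66 log units; beyond the scatter) in the opposite direction. Added chain carbon therefore does not go with a lower number at both places: compound 2 fits that trend, while compound 3 goes against it. What lies behind the rise at this aromatic carbon, para to a large group, cannot be told from the data, as nothing measured here bears on it.

Still open, going by these compounds, is whether a methyl, a methoxy group or a carboxylic acid at the same ring carbon would raise the number as butyl does. Equally open, on these data alone, is whether a longer chain on the amide-type nitrogen would lower it further.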